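Swapping the acyl group on compound 2: an expected clearance

A few compounds are considered here, and "the series" means these few. Any claim that something is new, unique, unknown or untested is made for them only; others in the source may bear on it.

Measured compounds:
Compound 1, `Cc1ccc(C(=O)Nc2cn3ncnc3c(O[C@H]3CCN(C(=O)CC(C(F)(F)F)C(F)(F)F)[C@@H](C)C3)c2C)cn1`, gives 2.5 mL/min/kg in an ADME assay on the whole organism (Mus musculus) for pharmacokinetics, using cassette dosing; on this read-out lower numbers stand for slow clearance and higher numbers for fast clearance.
Compound 2, `Cc1ccc(C(=O)Nc2cn3ncnc3c(CN3CCN(C(=O)C4CCCC4)[C@@H](C)C3)c2C)cn1`, gives 18.3 mL/min/kg in this assay.
Compound 3, `Cc1ccc(C(=O)Nc2cc(F)cc(CN3CCN(C(=O)C4CCCC4)[C@@H](C)C3)c2C)cn1`, gives 33.3 mL/min/kg in this assay.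

Among these three numbers, compound 2 stands second highest. Its nearest neighbour is compound 3, whose number is higher, but the gap between the two lies within the usual scatter, so no order between them can be read. The furthest is compound 1, whose number is lower by a margin beyond the scatter.

Compound 4, `Cc1ccc(C(=O)Nc2cn3ncnc3c(CN3CCN(C(=O)CC(C(F)(F)F)C(F)(F)F)[C@@H](C)C3)c2C)cn1`, has not yet been measured. It differs from compound 2 in one place: 3,3,3-trifluoro-2-(trifluoromethyl)propyl in place of cyclopentyl on a carbonyl carbon. Compound 1 carries the same 3,3,3-trifluoro-2-(trifluoromethyl)propyl group on a carbonyl carbon, though on a different core, and its value in this assay is the lowest of the three.

On that basis the step from compound 2 to compound 4 is expected to go toward slower clearance, by a moderate amount, estimated as a 1.8-fold lower number from compound 2 to compound 4 (0.26 log units; within the scatter). Compound 4 is therefore estimated at 10 mL/min/kg, within a range from 4 mL/min/kg to 25 mL/min/kg.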

Compound 4, clearance: 18.3 mL/min/kg
Compound 4: the middle estimate sits 1.8-fold (0.26 log units) below what was measured; the measured number falls inside the stated range.
By their numbers in this assay, from the lowest: compound 1; then compounds 2, 4 and 3 (each within the scatter of the next).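

In this assay the exchange on the carbonyl carbon gives no change at the digits printed from compound 2 to compound 4 (within the scatter), even though cyclopentyl, with its five-membered ring of carbon only and 5 heavy atoms, gives way to the open 3,3,3-trifluoro-2-(trifluoromethyl)propyl group with 10 heavy atoms, 6 of them fluorine. For the compounds shown here, this is the first reading at this position in which only the acyl group differs, and it shows that these two groups cannot be told apart on this read-out on the shared core. Putting the group on this core does not by itself bring the number to the level of compound 1, 2.5 mL/min/kg, and compound 1 differs in more than one place, so no single change can be named for its number. Nothing shown accounts for why the two groups read alike.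

Going by these compounds, whether an acyl group bearing an amine, a carboxylic acid or a longer unfluorinated alkyl chain would read the same at this position remains open. So does whether the same exchange would read alike on the core of compound 3, which carries cyclopentyl and gives 33.3 mL/min/kg.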